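The source may hold more compounds than are shown below. What is called first, only, known or untested is meant among the compounds shown, and "the series" means these compounds.

Compound 1 `Cc1cc(=O)oc2cc(OCc3cn(-c4ccc(F)cc4F)nn3)ccc12` was examined in an ADME assay on Huh-7 cells (Homo sapiens) for cytotoxicity, read by MTT assay, with a stated time of 72 h (a lower number here means that less compound is tolerated, a higher number that more compound is tolerated), where compound 1 gives > 100 ug/mL, a limit of the assay rather than a number. Compound 2 `CC(=O)Nc1ccc(-n2cc(COc3ccc4c(C)cc(=O)oc4c3)nn2)cc1` shares the same core. In this assay compound 2 gives > 100 ug/mL, again a limit. Both values therefore sit at the limit of > 100 ug/mL in this assay, at which 2 of the 2 values shown sit, and compound 1 stands at that limit alongside compound 2, with no number of its own. Compound 3 `COC(=O)Cn1cc(COc2ccc3c(C)cc(=O)oc3c2)nn1` differs from compound 1 in one place: (methoxycarbonyl)methyl in place of 2,4-difluorophenyl on an aromatic nitrogen. Within the data shown here, no step between measured compounds is available to size the effect of such a change. Since the measured compounds sit at the limit, the step expected from compound 1 to compound 3 in this assay is a number no higher from compound 1 to compound 3 (the limit leaves the size open), none beyond the scatter. Compound 3 is thus estimated at 100 ug/mL in this assay, with a range from 50 ug/mL to 200 ug/mL.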

Compound 3, half-maximal cytotoxic concentration: > 100 ug/mL
Compound 3 was reported as a limit; the forecaster's own chance of this, stated with the estimate: 75%; the middle value lies on the limit itself.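

In this assay, no step can be read from compound 1 to compound 3, since each gives only a limit: the limit of > 100 ug/mL in this assay, at which 3 of the 3 values shown sit.

The compounds shown leave open whether (methoxycarbonyl)methyl in place of 2,4-difluorophenyl on an aromatic nitrogen changes the tolerated concentration in this assay, and by how much.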